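Nitro to Amino Exchange Carried onto a Second Core

The source may report more compounds than this note shows. Statements on the series, on what has been measured and on what is new or still open speak of the compounds shown alone.

Compound 1 `COc1ccc(NC(=O)c2cc(OC)c(OC)c(OC)c2)cc1[N+](=O)[O-]` gives 2900 nM in a functional assay on MDA-MB-468 cells (Homo sapiens) for antiproliferative activity, read by MTT assay, with a stated time of 72 h; on this read-out lower numbers stand for stronger inhibition and higher numbers for weaker inhibition. Compound 2 `COc1ccc(NC(=O)c2cc(OC)c(OC)c(OC)c2)cc1N` differs by amino in place of nitro on an aromatic carbon and gives 2000 nM in this assay; the step is a 1.5-fold lower number from compound 1 to compound 2 (0.16 log units; within the scatter). Compound 3 `COc1ccc(C(=O)Nc2cc(OC)c(OC)c(OC)c2)cc1[N+](=O)[O-]` holds the same atoms as compound 1 joined differently; the difference between the two cores is not broken down here. In this assay compound 3 gives 3000 nM, which sits within the scatter of compound 1 and of compound 2.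

Compound 4 `COc1ccc(C(=O)Nc2cc(OC)c(OC)c(OC)c2)cc1N` carries the same change on the core of compound 3: amino in place of nitro on an aromatic carbon. The surroundings of the changed position read the same in both cases. The step is expected to be a 1.4-fold lower number from compound 3 to compound 4 (0.15 log units; within the scatter), resting on a 1.5-fold lower number from compound 1 to compound 2 (0.16 log units; within the scatter), which lay within the scatter. Compound 4 is therefore estimated at 2100 nM in this assay, with a likely range from 1000 nM to 4500 nM.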

Compound 4, half-maximal inhibitory concentration: > 100000 nM
Compound 4 gave a limit, no number (the forecaster's own chance of this, stated with the estimate: 3%); middle value at least 47-fold (1.67 log units) from the limit.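

In this assay compound 4 gives > 100000 nM, which is a limit of the assay and not a number. Amino in place of nitro on an aromatic carbon does not carry over from the core of compound 1 to the core of compound 3, where the step is an at least 33-fold higher number from compound 3 to compound 4 (1.52 log units; beyond the scatter), and the two steps differ: the same change on two cores in this assay, a 1.5-fold lower number (0.16 log units; within the scatter) from compound 1 to compound 2 and an at least 33-fold higher number (1.52 log units; beyond the scatter) from compound 3 to compound 4, at least 48-fold (1.68 log units) apart, beyond the scatter of two such steps. With one pair on each core, this shows only that the outcome of the change differs between these two cores; it gives no exact size for the second step and no reason for the gap.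

Open, as far as these compounds go, is whether another group at the same place, such as hydroxyl or dimethylamino, follows nitro or amino on the core of compound 3. Also open, from the compounds shown here alone, is whether an ethoxy group in place of the methoxy group alters the gap between the two cores.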